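The source may report more compounds than this note shows. Statements on the series, on what has been measured and on what is new or still open speak of the compounds shown alone.

Measured so far:
- compound 1 `CC(C)c1[nH]cnc1/C=c1\[nH]c(=O)/c(=C/c2cccc(C(=O)c3ccc(F)cc3)c2)[nH]c1=O`: 0.8 nM
- compound 2 `O=C(c1ccc(F)cc1)c1cccc(/C=c2\[nH]c(=O)/c(=C/c3nc[nH]c3C3CC3)[nH]c2=O)c1`: 1.4 nM

Both numbers come from a functional assay on HT-29 cells (Homo sapiens) for cytotoxicity, read by MTT assay, with a stated time of 72 h; a lower number here means a stronger inhibitor, a higher number a weaker inhibitor. For the measured compounds named here, the only measured step, cyclopropyl in place of isopropyl on an aromatic carbon, is a 1.8-fold higher number from compound 1 to compound 2 (0.24 log units; within the scatter). Going by the values given here, compound 2 therefore stands level with the one other measured compound.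

The next compound, compound 3 `O=C(c1ccc(F)cc1)c1cccc(/C=c2\[nH]c(=O)/c(=C/c3c[nH]cn3)[nH]c2=O)c1`, is compound 2 with hydrogen in place of cyclopropyl on an aromatic carbon. The measured step bears on this only in part. It swapped one carbon group for another, whereas here the group goes and only hydrogen takes its place. Among the compounds with values here, no measured compound lacks the group, so the data give no direct size for this loss.

Both compounds that carry a group there give very small numbers, compound 1 0.8 nM and compound 2 1.4 nM, and removing the group is a larger change than swapping it. A higher number in this assay, meaning a weaker inhibitor, is therefore expected, though with wide uncertainty. The expected step is an 11-fold higher number from compound 2 to compound 3 (1.03 log units; beyond the scatter). For compound 3 the estimated value is 15 nM, with an expected range of 3 nM to 80 nM.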

Compound 3, half-maximal inhibitory concentration: 5.1 nM
The estimate for compound 3 lay 2.9-fold (0.47 log units) above the measured number; the measured number falls inside the stated range.
By their numbers in this assay, from the lowest: compounds 1 and 2 (each within the scatter of the next); then compound 3.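

In this assay, stripping the group from this aromatic carbon of the five-membered ring, so that 5-cyclopropyl-1H-imidazol-4-yl becomes 1H-imidazol-4-yl, gives a 3.6-fold higher number from compound 2 to compound 3 (0.56 log units; beyond the scatter), and the matching loss of isopropyl gives a 6.4-fold higher number from compound 1 to compound 3 (0.80 log units; beyond the scatter). For the compounds shown here, these are the first changes at this position to go beyond the scatter, so having a carbon group here counts for something, whereas the swap between isopropyl and cyclopropyl could not show that. Both steps are modest, however, and compound 3 still gives 5.1 nM, so the group helps but is not needed for a very small number, and nothing available explains why its loss matters.

The compounds shown leave open how small a carbon group can be and still match isopropyl and cyclopropyl, as a single methyl group would test, and whether a longer chain such as n-butyl would lower the number further or raise it. They also leave open how a group other than a plain carbon group, such as an amine or a carboxylic acid, would behave on this same carbon.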